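The source may report more compounds than this note shows. Statements on the series, on what has been measured and on what is new or still open speak of the compounds shown alone.

Measured so far:
Compound 1 `Clc1ccc(-c2cc(-c3ccsc3)nc(-c3ccccc3Cl)c2)o1` gives 0% in an assay on isolated protein for inhibition of DNA topoisomerase 1 (Homo sapiens), tested at 100 uM; a higher number here means a stronger effect of the compound at the concentration tested, a lower number a weaker effect.
Compound 2 `Clc1ccc(-c2cc(-c3ccc(Cl)o3)cc(-c3ccsc3)n2)cc1` gives 29.8% in this assay.

For the measured compounds named here, of these two numbers compound 2 stands highest; its only neighbour is compound 1, and the step of a number 29.8 percentage points higher from compound 1 to compound 2 (beyond the scatter) lies beyond the scatter. Compound 3 `Clc1ccc(-c2cc(-c3ccsc3)nc(-c3ccccn3)c2)o1` has not yet been measured. It differs from compound 2 in one place: pyridin-2-yl in place of 4-chlorophenyl on an aromatic carbon. Going by the values given here, the single measured step concerns the same position, where a 2-chlorophenyl group gave way to a 4-chlorophenyl group, and it was modest. Among the compounds with values here, no measured step shows a pyridin-2-yl group at this position, so the direction of the new change is uncertain. Within the data shown here, since a number 29.8 percentage points higher from compound 1 to compound 2 (beyond the scatter) shows that this position can move the number by a modest amount, a step of similar or smaller size is expected, more likely downward as compound 2 is the higher of only two numbers. Compound 3 is therefore estimated at 12%, between 0% and 35%, an expected step of a number 17.8 percentage points lower from compound 2 to compound 3 (beyond the scatter).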

Compound 3, a percentage reported as inhibition, at one concentration (the size of the read-out at that concentration, not a potency): 0%
The estimate for compound 3 lay 12 percentage points above the measured number; low and high end bracket the measured number.
By their numbers in this assay, from the lowest: compounds 1 and 3 (each within the scatter of the next); then compound 2.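

Replacing the 4-chlorophenyl group with pyridin-2-yl gives a number 29.8 percentage points lower from compound 2 to compound 3 (beyond the scatter) in this assay, so a second replacement at this position also fails to keep the reading of compound 2. The step of no change at the digits printed from compound 1 to compound 3 (within the scatter) leaves the 2-chlorophenyl and pyridin-2-yl groups level, which means that among the three groups tried here, only 4-chlorophenyl stands clear of the others. No independent measurement is available to explain this pattern.

A plain phenyl group or a 4-aminophenyl group at this position would help show whether the number for compound 2 depends on the chlorine or on the carbon-only ring. As far as these compounds go, the 5-chlorofuran-2-yl and thiophen-3-yl groups stay the same throughout, so what they contribute remains open.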